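Bromo in place of methoxy: one step not yet measured

The compounds below may be only part of what the source reports. "The series", "measured", "known", "first", "only" and "open" are said of these compounds alone.

compound 1 `CC(C)CC(=O)CC1Oc2cc(O)ccc2C=C1c1ccc(O)cc1`: 139000 nM
compound 2 `CCc1ccc(C(=O)CC2Oc3cc(O)ccc3C=C2c2ccc(O)cc2)cc1`: 377000 nM
compound 3 `COc1ccc(C(=O)CC2Oc3cc(O)ccc3C=C2c2ccc(O)cc2)cc1`: 37000 nM

In a functional assay on SHEP cells (Homo sapiens) for antiproliferative activity, read by spectrophotometry and resazurin assay, with a stated time of 72 h (a lower number here means a stronger inhibitor, a higher number a weaker inhibitor), compound 3 gives 37000 nM, the lowest of the three numbers, which makes it the strongest inhibitor of the set. Its lead is clear: the measured steps are a 3.8-fold lower number from compound 1 to compound 3 (0.57 log units; beyond the scatter) and a 10-fold lower number from compound 2 to compound 3 (1.01 log units; beyond the scatter).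

The next compound, compound 4 `O=C(CC1Oc2cc(O)ccc2C=C1c1ccc(O)cc1)c1ccc(Br)cc1`, changes one group of compound 3: bromo in place of methoxy on an aromatic carbon. Put simply, the ring goes from 4-methoxyphenyl to 4-bromophenyl, with bromo in place of methoxy on an aromatic carbon.

For the measured compounds named here, no measured compound carries bromo, so the evidence is indirect. The closest guide is the large step of a 10-fold lower number from compound 2 to compound 3 (1.01 log units; beyond the scatter), since it changes only the group at this same place. Read backwards, it shows that ethyl there gives a much higher number than methoxy. The modest step of a 3.8-fold lower number from compound 1 to compound 3 (0.57 log units; beyond the scatter) also ends at compound 3 with a lower number. On this thin evidence, a rise in this assay seems more likely than a fall, though probably a smaller one than the ethyl case.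

The expected change is a 2.7-fold higher number from compound 3 to compound 4 (0.43 log units; beyond the scatter). Compound 4 is estimated at 100000 nM, within an expected range of 25000 nM to 400000 nM.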

Compound 4, half-maximal inhibitory concentration: 33000 nM
For compound 4 the middle estimate is 3.0-fold (0.48 log units) above the measured one; low and high end bracket the measured number.
By their numbers in this assay, from the lowest: compounds 4 and 3 (each within the scatter of the next); then compound 1; then compound 2.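

The result in this assay is that swapping methoxy for bromo on this aromatic carbon makes no meaningful difference (a 1.1-fold lower number from compound 3 to compound 4 (0.05 log units; within the scatter)), even though methoxy brings an oxygen and a hydrogen-bond acceptor and bromo brings neither. Before this, the single change from ethyl to methoxy at this place could have suggested that methoxy itself was special, but bromo also gives a large step away from ethyl (an 11-fold lower number from compound 2 to compound 4 (1.06 log units; beyond the scatter)) and a modest one away from the isobutyl group on the carbonyl carbon (a 4.2-fold lower number from compound 1 to compound 4 (0.62 log units; beyond the scatter)), so among these three groups on the ring, ethyl is the one that stands apart. No measurement here accounts for why ethyl differs from methoxy and bromo, so the reason remains unknown.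

From the compounds shown here alone, it remains open whether a nitrile, a carboxylic acid or an amine at this place would track methoxy and bromo or track ethyl, and whether a fluoro or chloro group would match bromo. The shared core is the same in all four compounds, so what its parts contribute to the numbers cannot be told from this set.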